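The source may hold more compounds than are shown below. What is called first, only, known or untested is meant among the compounds shown, and "the series" means these compounds.

The three measured compounds share one core and differ only in the aryl group attached to it. Compound 1 `COc1cccc(-c2cc(-c3cc(C(C)C)c(O)cc3C)[nH]c(=O)c2C#N)c1` gives 38% in a functional assay for inhibition, tested at 60 ug/mL; on this read-out lower numbers stand for a weaker effect and higher numbers for a stronger effect at the one concentration tested. Compound 2 `COc1ccc(-c2cc(-c3cc(C(C)C)c(O)cc3C)[nH]c(=O)c2C#N)c(OC)c1` gives 48.5% in this assay, and compound 3 `COc1cc(-c2cc(-c3cc(C(C)C)c(O)cc3C)[nH]c(=O)c2C#N)ccc1O` gives 37.5% in this assay. Compound 3 thus stands level with compound 1, since a number 0.5 percentage points lower from compound 1 to compound 3 (within the scatter), and beneath compound 2, since a number 11 percentage points lower from compound 2 to compound 3 (beyond the scatter). The remaining step, a number 10.5 percentage points higher from compound 1 to compound 2 (beyond the scatter), is a modest move of similar size.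

Within the data shown here, compound 4 `Cc1cc(O)c(C(C)C)cc1-c1cc(-c2ccc(N(C)C)cc2)c(C#N)c(=O)[nH]1` has not yet been measured in this assay. 4-(dimethylamino)phenyl in place of 4-hydroxy-3-methoxyphenyl on an aromatic carbon No measured step exchanges this aryl group for the one that enters here, so nothing bears on it directly; the three steps among compounds 1, 2 and 3 show only that swapping one methoxy- or hydroxy-bearing phenyl for another moves the read-out either not at all or modestly. Because a number 11 percentage points lower from compound 2 to compound 3 (beyond the scatter) and a number 10.5 percentage points higher from compound 1 to compound 2 (beyond the scatter) are the widest moves seen, a step of comparable size in either direction, or none beyond the scatter, is the most that can be expected. Compound 4 is therefore expected to give about 40% in this assay, with a range from 24% to 58%. That estimate means a number 2.5 percentage points higher from compound 3 to compound 4 (within the scatter), which is expected to remain inside the spread already seen.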

Compound 4, a percentage reported as inhibition, at one concentration (the size of the read-out at that concentration, not a potency): 53%
For compound 4 the middle estimate is 13 percentage points below the measured one; measured number inside the range.
By their numbers in this assay, from the lowest: compounds 3 and 1 (each within the scatter of the next); then compounds 2 and 4 (each within the scatter of the next).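

At this position the aryl group need not carry oxygen at all: in this assay, 4-(dimethylamino)phenyl, with no hydrogen-bond donor and nitrogen as its only heteroatom, gives a number 15.5 percentage points higher from compound 3 to compound 4 (beyond the scatter) and a number 15 percentage points higher from compound 1 to compound 4 (beyond the scatter) and so exceeds both of these compounds by a modest step beyond the scatter. The comparison with the best earlier compound gives a number 4.5 percentage points higher from compound 2 to compound 4 (within the scatter) and so places 4-(dimethylamino)phenyl level with 2,4-dimethoxyphenyl, which means two aryl groups with different substituents reach the same upper level on this shared core, and the new group adds no separate gain over the dimethoxy pattern. Nothing measured here accounts for why this aryl group reads higher than the 3-methoxyphenyl and 4-hydroxy-3-methoxyphenyl groups.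

As far as these compounds go, it remains open how a phenyl bearing a plain amino group, a morpholine ring or a carboxylic acid would read at this place, and whether the dimethylamino group would read the same elsewhere on the phenyl ring. From the compounds shown here alone, with one concentration tested, it is also open whether these compounds keep the same order at other concentrations.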